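The source may hold more compounds than are shown below. What is called first, only, known or untested is meant among the compounds shown, and "the series" means these compounds.

Of the compounds shown here, three with a shared core have numbers so far in a functional assay on EA.hy 926 cells (Homo sapiens) for cytotoxicity, read by MTT assay, with stated times of 24 h and 12 h; on this read-out lower numbers stand for an effect already at smaller amounts and higher numbers for an effect only at larger amounts of compound: compound 1 (`Cc1nc(C)c(C(=O)Oc2ccccc2/C=C/C(=O)O)nc1C`) gives 36700 nM, compound 2 (`COc1ccc(OC(=O)c2nc(C)c(C)nc2C)c(/C=C/C(=O)O)c1`) gives 48600 nM and compound 3 (`CCOC(=O)/C=C/c1cc(OC)ccc1OC(=O)c1nc(C)c(C)nc1C`) gives 105000 nM. Compound 2 therefore lies within the scatter of compound 1, while compound 3 stands clear of it on the high side. Compound 4 (`Cc1nc(C)c(C(=O)Oc2ccc(Cl)cc2/C=C/C(=O)O)nc1C`) is still unmeasured. It differs from compound 2 by a single swap, chloro in place of methoxy on an aromatic carbon. The closest evidence is the step that put methoxy on that carbon, a 1.3-fold higher number from compound 1 to compound 2 (0.12 log units; within the scatter), which is small. The other step, a 2.2-fold higher number from compound 2 to compound 3 (0.33 log units; beyond the scatter), is modest, but it concerns ethyl in place of hydrogen on an oxygen next to a carbonyl group, a change compound 4 does not make. Among the compounds with values here, no chloro compound has been measured, so this remains only a guide. No shift beyond the scatter is expected in this assay, and the estimated change is a 1.2-fold lower number from compound 2 to compound 4 (0.06 log units; within the scatter). Compound 4 is expected at 42000 nM, with an estimated range from 20000 nM to 85000 nM.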

Compound 4, half-maximal effective concentration: 95200 nM
Estimate against measurement, compound 4: 2.3-fold (0.36 log units) below; measured number outside the range, above it.
By their numbers in this assay, from the lowest: compounds 1, 2, 4 and 3 (each within the scatter of the next, the first and the last beyond it).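

In this assay, the carbon para to a large group does not tolerate every change equally: chloro in place of hydrogen gives a 2.6-fold higher number from compound 1 to compound 4 (0.41 log units; beyond the scatter) and so moves the number beyond the scatter, which methoxy on the same carbon did not do. Yet the direct swap gives a 2.0-fold higher number from compound 2 to compound 4 (0.29 log units; within the scatter) and stays within the scatter, so chloro and methoxy cannot be told apart at this position, even though only chloro clears the scatter when compared with hydrogen. Nothing available here explains why the number moves with chloro.

Still open, on these data alone, is whether other groups on this carbon, such as fluoro, an amine or a longer alkyl chain, would move the number further or leave it unchanged. As far as these compounds go, it is also open whether the ethyl ester would raise the number on the chloro compound as it does on the methoxy one.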